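Swapping the Hydroxypropyl Arm for Isopropyl on a Myosin Inhibitor

This account rests on a few compounds, and the source may have more. Where it says the series, first, only, none or still open, it means among the compounds named here.

Compound 1, `C/C(=N\Cc1cccnc1)c1c(O)c2ccccc2oc1=O`, in an assay on isolated protein for inhibition of myosin-2 (Bos taurus), read by spectrophotometry, with a stated time of 24 min; a lower number here means a stronger inhibitor, a higher number a weaker inhibitor: 17000 nM
Compound 2, `C/C(=N\CCCO)c1c(O)c2ccccc2oc1=O`, in this assay: 37000 nM

For the measured compounds named here, of the two measured compounds, compound 2 gives the highest number; the only measured step, a 2.2-fold higher number from compound 1 to compound 2 (0.34 log units; beyond the scatter), separates them. Compound 3, `C/C(=N\C(C)C)c1c(O)c2ccccc2oc1=O`, differs from compound 2 by isopropyl in place of 3-hydroxypropyl on a double-bonded nitrogen. Going by the values given here, the single measured step traded a ring for a hydroxyl-bearing chain rather than removing a hydroxyl, so it bears on this change only loosely. The step expected is a 1.5-fold lower number from compound 2 to compound 3 (0.17 log units; within the scatter), a modest move toward a lower number that may sit within the scatter. Compound 3 is therefore estimated at 25000 nM, between 8000 nM and 80000 nM.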

Compound 3, half-maximal inhibitory concentration: >= 100000 nM
Compound 3 gave a limit, no number (the forecaster's own chance of this, stated with the estimate: 15%); at least 4.0-fold (0.60 log units) between middle value and limit.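

Compound 3 gives only a limit of the assay, not a number: the limit of >= 100000 nM in this assay, at which 1 of the 3 values shown sits. The group on the double-bonded nitrogen therefore matters in this assay: isopropyl in place of 3-hydroxypropyl gives an at least 2.7-fold higher number from compound 2 to compound 3 (0.43 log units; beyond the scatter), and isopropyl in place of (pyridin-3-yl)methyl gives an at least 5.8-fold higher number from compound 1 to compound 3 (0.76 log units; beyond the scatter). Of the three groups shown, isopropyl alone leaves no measured number.

Still open, going by these compounds, is whether the loss follows the hydroxyl itself or the chain that carries it. Also open, on these data alone, is how an amine in place of that hydroxyl would read.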